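The source may hold more compounds than are shown below. What is called first, only, known or untested is meant among the compounds shown, and "the series" means these compounds.

Compound 1 `C#CCn1cc(C(=O)NC(CC(=O)Nc2ccccc2)c2ccccc2)c(=O)c2cccnc21` and compound 2 `C#CCn1cc(C(=O)NC(CC(=O)Nc2ccccc2)c2ccccc2)c(=O)c2cc(F)c(Cl)nc21` share the same core and differ only in the substitution of the core. In a functional assay on ECV-304 cells (Homo sapiens) for cytotoxicity, read by MTT assay, with a stated time of 72 h (on this read-out lower numbers stand for stronger inhibition and higher numbers for weaker inhibition), compound 1 shows only the limit > 10000 nM. In this assay compound 2 likewise shows only the limit > 10000 nM, so compound 2 stands at the limit of > 10000 nM in this assay, at which 2 of the 2 values shown sit, and no number is known for it. Compound 3 `C#CCn1cc(C(=O)NC(CC(=O)NC2CCCC2)c2ccccc2)c(=O)c2cc(F)c(Cl)nc21` carries the change (cyclopentyl in place of phenyl on an amide-type nitrogen). The expected step that the limit leaves unreadable from compound 2 to compound 3 is none beyond the scatter. Compound 3 is estimated at 15000 nM, expected between 5000 nM and 50000 nM, most likely again reported as a limit.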

Compound 3, half-maximal inhibitory concentration: 5100 nM
The estimate for compound 3 lay 2.9-fold (0.47 log units) above the measured number, and the stated range covers the measured number.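

Going by these compounds alone, the amide-type nitrogen is the first place where a change moves a compound off the limit: cyclopentyl in place of phenyl gives an at least 1.9-fold lower number from compound 2 to compound 3 (0.29 log units; that floor lies within the scatter) in this assay. From the compounds shown here alone, only a floor can be read for this step, so its true size stays unknown. Compound 2 remains a limit and not a number, as does compound 1: the limit of > 10000 nM in this assay, at which 2 of the 3 values shown sit.

The compounds shown leave open how a cyclohexyl group, a longer alkyl chain or an amine-bearing chain would read on this nitrogen. Also open, going by these compounds, is whether cyclopentyl gives a number on the core of compound 1.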